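The source may report more compounds than this note shows. Statements on the series, on what has been measured and on what is new or still open speak of the compounds shown alone.

The measured compounds:
Compound 1, `COc1ccc(-c2cc(C(=O)/C=C/c3ccc(C)cc3)nc3cc(-c4ccccc4)nn23)cc1OC`; in a functional assay on MDA-MB-231 cells (Homo sapiens) for antiproliferative activity, read by MTT assay, with a stated time of 24 h (on this read-out higher numbers stand for weaker inhibition and lower numbers for stronger inhibition), compound 1 gives 22600 nM.
Compound 2, `COc1ccc(-c2cc(C(=O)/C=C/c3cc(OC)c(OC)c(OC)c3)nc3cc(-c4ccccc4)nn23)cc1OC`; in this assay compound 2 gives 16700 nM.
Compound 3, `COc1cc(-c2cc(C(=O)/C=C/c3ccc(C)cc3)nc3cc(-c4ccccc4)nn23)cc(OC)c1OC`; in this assay compound 3 gives 18600 nM.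

Compound 1 carries the highest of the three numbers. The nearest to it is compound 3, reached by a 1.2-fold lower number from compound 1 to compound 3 (0.08 log units; within the scatter); the furthest is compound 2, reached by a 1.4-fold lower number from compound 1 to compound 2 (0.13 log units; within the scatter). Both steps stay within the scatter, so the three compounds cannot be put in order.

Compound 4, `COc1ccc(-c2cc(/C=C/C(=O)c3ccc(Cl)cc3)nc3cc(-c4ccccc4)nn23)cc1OC`, is not yet measured. It differs from compound 1 in one place: 2-((4-chlorophenyl)carbonyl)ethenyl in place of (2-(4-methylphenyl)ethenyl)carbonyl on an aromatic carbon. Neither measured step bears directly on this change. For the measured compounds named here, the step to compound 2 swaps one aryl group for another, and the step to compound 3 adds a methoxy to an aryl ring, while both keep the carbonyl and the double bond in the same arrangement; no measured compound shows the consequence of placing the carbonyl on the aryl side, and none carries a chlorine. With no guidance from the measured steps and with both of them within the scatter, compound 4 is expected to move by a 1.2-fold lower number from compound 1 to compound 4 (0.08 log units; within the scatter), with no step beyond the scatter anticipated. Compound 4 is therefore estimated at 19000 nM, with a range from 6000 nM to 55000 nM.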

Compound 4, half-maximal inhibitory concentration: 17100 nM
The estimate for compound 4 lay 1.1-fold (0.05 log units) above the measured number; the measured number falls inside the stated range.
By their numbers in this assay, from the lowest: compounds 2, 4, 3 and 1 (each within the scatter of the next).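

At the aromatic carbon opposite the ring nitrogen, the exchange of (2-(4-methylphenyl)ethenyl)carbonyl for 2-((4-chlorophenyl)carbonyl)ethenyl gives, in this assay, a 1.3-fold lower number from compound 1 to compound 4 (0.12 log units; within the scatter), so the first change shown to the arrangement of the carbonyl and the double bond, and the first chlorine, still leave compound 4 within the scatter of compound 1. For the compounds shown here, the heavy-atom count of the group stays the same, but the single step changes both the side on which the carbonyl stands and the substituent on the aryl ring, so the contribution of each cannot be told apart. Nothing measured on these compounds offers an explanation of this result.

The compounds shown leave open what the reversed arrangement does when the aryl ring keeps its methyl group, and what chlorine does when the carbonyl stays in the arrangement of compound 1. They also leave open whether a different group at this aromatic carbon, such as a chain ending in an amine or a carboxylic acid, would give a step beyond the scatter.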